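Urea substituent change in a kinase-inhibitor-like series

A few compounds are considered here, and "the series" means these few. Any claim that something is new, unique, unknown or untested is made for them only; others in the source may bear on it.

Measured so far:
compound 1 `CN(c1ccc(NC(=O)Nc2ccccc2)cc1)c1ccnc(Nc2cccc(CS(C)(=O)=O)c2)n1` — 0.2 nM
compound 2 `CN(c1ccc(NC(=O)Nc2cc(C(F)(F)F)ccc2F)cc1)c1ccnc(Nc2ccc(S(N)(=O)=O)cc2)n1` — 8 nM
compound 3 `CCNC(=O)Nc1ccc(N(C)c2ccnc(Nc3ccc(CS(C)(=O)=O)cc3)n2)cc1` — 27 nM

In a functional assay on HUVEC cells (Homo sapiens) for inhibition (a lower number here means a stronger inhibitor, a higher number a weaker inhibitor), compound 1 gives the lowest number of the three; compound 2 sits well beyond the scatter above it, and compound 3, an ethyl urea that also differs elsewhere, further still. Compound 4 `CCCCNC(=O)Nc1ccc(N(C)c2ccnc(Nc3cccc(CS(C)(=O)=O)c3)n2)cc1` is the next compound; its change from compound 1 is butyl in place of phenyl on an amide-type nitrogen. Going by the values given here, no measured pair shows this change alone. As far as these compounds go, compound 3 carries an alkyl group on the same amide-type nitrogen and gives a much higher number than compound 1, but two places differ, so the share of the urea in that gap is unknown. For compound 4 a weakening step a 20-fold higher number from compound 1 to compound 4 (1.30 log units; beyond the scatter) is expected, beyond the scatter. Compound 4 is estimated at 4 nM, range 0.8 nM to 25 nM.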

Compound 4, half-maximal inhibitory concentration: 2 nM
Beside the measured number, compound 4's estimate is 2.0-fold (0.30 log units) above it; the measured number falls inside the stated range.
By their numbers in this assay, from the lowest: compound 1; then compound 4; then compound 2; then compound 3.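

In this assay, going by these compounds alone, butyl in place of phenyl on the amide-type nitrogen gives a 10-fold higher number from compound 1 to compound 4 (1.00 log units; beyond the scatter) as the first reading of this change alone. The aromatic ring at this position is therefore not essential for activity, since compound 4 with its open chain still gives 2 nM in this assay. No supporting data bear on the origin of this step.

As far as these compounds go, whether a cyclohexyl ring, a longer chain or a chain ending in an amine would recover the lost activity remains open. The effect of chain length cannot be read, as compound 3 and compound 4 differ in two places.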